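Adding a Third Methoxy Group to Compound 3

The source may report more compounds than this note shows. Statements on the series, on what has been measured and on what is new or still open speak of the compounds shown alone.

Compound 3 `COc1ccc(C2CC(c3cc(Cl)c(C)cc3O)=NN2c2ccc(S(N)(=O)=O)cc2)cc1OC` carries a sulfonamide-bearing aryl on the shared core and a 3,4-dimethoxyphenyl on a saturated ring carbon. In a functional assay on NCI-H23 cells (Homo sapiens) for antiproliferative activity, with a stated time of 48 h (a lower number here means a stronger inhibitor of growth, a higher number a weaker inhibitor of growth), compound 3 gives 3110 nM. Its two neighbours differ only in the aryl group on that saturated ring carbon: compound 1 `Cc1cc(O)c(C2=NN(c3ccc(S(N)(=O)=O)cc3)C(c3ccccc3O)C2)cc1Cl` gives 2090 nM and compound 2 `Cc1cc(O)c(C2=NN(c3ccc(S(N)(=O)=O)cc3)C(c3ccccc3Cl)C2)cc1Cl` gives 1790 nM. The step from compound 1 to compound 3 is a 1.5-fold higher number from compound 1 to compound 3 (0.17 log units; within the scatter), that from compound 2 to compound 3 is a 1.7-fold higher number from compound 2 to compound 3 (0.24 log units; within the scatter), and the step from compound 1 to compound 2 is a 1.2-fold lower number from compound 1 to compound 2 (0.07 log units; within the scatter); all three lie within the scatter, so compound 3 stands level with the others.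

Compound 4 `COc1ccc(C2CC(c3cc(Cl)c(C)cc3O)=NN2c2ccc(S(N)(=O)=O)cc2)c(OC)c1OC` is obtained from compound 3 by a single change: methoxy in place of hydrogen on an aromatic carbon. Among the measured compounds shown here, no measured pair adds a methoxy group, so the measured steps bear on this change only indirectly, by showing that swapping the whole aryl on this carbon moved this assay by no more than the scatter. On that basis compound 4 is expected to show no step beyond the scatter, with an expected step of a 1.0-fold higher number from compound 3 to compound 4 (0.01 log units; within the scatter). The estimate for compound 4 is 3200 nM, within a range from 1400 nM to 7500 nM.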

Compound 4, concentration for 50% growth inhibition: 2110 nM
Estimate against measurement, compound 4: 1.5-fold (0.18 log units) above; the range from low to high includes it.
By their numbers in this assay, from the lowest: compounds 2, 1, 4 and 3 (each within the scatter of the next).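

In this assay, among the compounds shown here, this is the first pair that adds a single methoxy group to the aryl on the saturated ring carbon, and going from 3,4-dimethoxyphenyl to 2,3,4-trimethoxyphenyl, with the new group ortho to a large group and ortho to a methoxy group, gives a step that stays within the scatter (a 1.5-fold lower number from compound 3 to compound 4 (0.17 log units; within the scatter)). The more heavily substituted aryl also stands level with the 2-chlorophenyl and 2-hydroxyphenyl compounds (a 1.2-fold higher number from compound 2 to compound 4 (0.07 log units; within the scatter); a 1.0-fold higher number from compound 1 to compound 4 (0.00 log units; within the scatter)), so all four aryl groups shown on this carbon sit within the scatter of one another, and no step among them separates any compound from the rest. No accompanying measurement bears on why this read-out stays level across these aryl groups.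

The compounds shown leave open whether an amine or a carboxylic acid on this aryl, or a longer alkyl chain in place of the aryl, would produce a step beyond the scatter. Going by these compounds, the sulfonamide-bearing aryl and the other aryl on the shared core are the same in all four compounds, so the effect of changing either one remains unknown.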